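Fluoro in place of methoxy on compound 2

The source may hold more compounds than are shown below. What is called first, only, known or untested is meant among the compounds shown, and "the series" means these compounds.

Compound 1 `Nc1ccc2oc(-c3cccc(F)c3)cc(=O)c2c1` reads > 125000 nM
Compound 2 `COc1cccc(-c2oc3ccc(N)cc3c(=O)c2OC)c1` reads 37000 nM

Going by the values given here, in an ADME assay on THP-1 cells (Homo sapiens) for cytotoxicity, read by flow cytometry and propidium iodide staining, with a stated time of 72 h (a lower number here means a stronger inhibitor, a higher number a weaker inhibitor), compound 2 stands at 37000 nM as the only true number so far. For compound 1 the reading of > 125000 nM in this assay is a limit of the assay and not a number.

Compound 3 `COc1c(-c2cccc(F)c2)oc2ccc(N)cc2c1=O` differs from compound 2 in one place, with fluoro in place of methoxy on an aromatic carbon and the rest unchanged. Among the compounds with values here, no measured pair isolates this change. Compound 1 also carries fluoro on an aromatic carbon, and its reading of > 125000 nM gives the expectation a lean toward weaker inhibition. Compound 3 is therefore expected to move only modestly: the estimated change is a 1.5-fold higher number from compound 2 to compound 3 (0.17 log units; within the scatter) and may stay close to the usual scatter. Compound 3 is expected at 55000 nM in this assay (estimated range 20000 nM to 125000 nM).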

Compound 3, half-maximal inhibitory concentration: 34000 nM
Beside the measured number, compound 3's estimate is 1.6-fold (0.21 log units) above it; the range from low to high includes it.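

In this assay, the step of a 1.1-fold lower number from compound 2 to compound 3 (0.04 log units; within the scatter) shows that on an aromatic carbon meta to a large group, fluoro in place of methoxy leaves the reading unchanged within the scatter. The change that does register is methoxy in place of hydrogen on an aromatic carbon, which gives an at least 3.6-fold lower number from compound 1 to compound 3 (0.56 log units; beyond the scatter). Compound 1 reads > 125000 nM, which is a limit of the assay and not a number, so only a lower bound can be put on that step: the limit of > 125000 nM in this assay, at which 1 of the 3 values shown sits.

The compounds shown place only methoxy and fluoro on that aromatic carbon, so it remains open how an amine or a nitrile there would read. Also open, on these data alone, is whether a longer chain, such as ethoxy, would act as the methoxy that separates compound 1 from compound 3 does.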